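The source may hold more compounds than are shown below. What is called first, only, known or untested is meant among the compounds shown, and "the series" means these compounds.

Two compounds of the series have been run in a functional assay on CCRF-CEM cells (Homo sapiens) for antiproliferative activity, read by sulforhodamine B assay, with a stated time of 48 h (a lower number here means a stronger inhibitor of growth, a higher number a weaker inhibitor of growth), and the third is pending. Compound 1 `COc1ccc(OC)c(/C=C/c2nnc(Nc3ccc(Cl)cc3)o2)c1` carries the shared core in a heteroaromatic linkage to the chloro-substituted ring. In this assay compound 1 gives > 100000 nM, which is a limit of the assay and not a number. Compound 2 `COc1ccc(OC)c(/C=C/C(=O)N/N=C/c2ccc(Cl)cc2)c1` keeps the same two aryl ends but joins them through an acylhydrazone linker. In this assay compound 2 gives > 100000 nM, again a limit rather than a number. Compound 2 therefore stands at the limit of > 100000 nM in this assay, at which 2 of the 2 values shown sit; no measured number separates it from compound 1, so no ordering of the two can be drawn.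

The pending compound 3 `COc1ccc(OC)c(/C=C/C(=O)N/N=C/c2ccccc2)c1` is compound 2 with the change (hydrogen in place of chloro on an aromatic carbon), that is, hydrogen in place of chloro on an aromatic carbon. For the measured compounds named here, no measured step between compounds exists to scale this change. Given that compound 2 sits at the limit, the step from compound 2 to compound 3 is expected to be a number no higher from compound 2 to compound 3 (the limit leaves the size open), none beyond the scatter in either direction. Compound 3 is expected to give 100000 nM, with a range from 30000 nM to 300000 nM, most likely as a limit again.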

Compound 3, concentration for total growth inhibition: > 100000 nM
Compound 3 was reported as a limit; the forecaster's own chance of this, stated with the estimate: 75%; the middle value sits exactly at the limit.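

In this assay, for the compounds shown here, compound 3 gives > 100000 nM, a limit and not a number, so no step from compound 2 to compound 3 can be read. The compounds shown leave open whether hydrogen in place of chloro changes growth inhibition at all, since the series rests on a single value: the limit of > 100000 nM in this assay, at which 3 of the 3 values shown sit.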